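The compounds below may be only part of what the source reports. "The series", "measured", "known", "first", "only" and "open" are said of these compounds alone.

Of the compounds shown here, three have been read so far in a functional assay on L02 cells (Homo sapiens) for inhibition, read by Griess assay, with stated times of 1 h and 24 h; on this read-out higher numbers stand for weaker inhibition and lower numbers for stronger inhibition. Compound 1 `CCCc1nn(C)c2c(NCc3ccc(F)cc3)nc(/C=C/c3nc(C)c(C)nc3C)nc12` gives > 1000000 nM, which is a limit and not a number. Compound 2 `COc1cc(/C=C/c2nccc(NC(C)C)n2)cc(OC)c1OC` gives < 40000 nM, also a limit. Compound 3 `CC(C)CNc1nc(/C=C/c2ccccc2)nc2ccsc12` gives > 1000000 nM, again only a limit, and so stands at the limit of > 1000000 nM in this assay, at which 2 of the 3 values shown sit. Compound 4 `Brc1ccc(Nc2nc(/C=C/c3ccccc3)nc3ccsc23)cc1` carries 4-bromophenyl in place of isobutyl on a nitrogen on an aromatic ring. For the measured compounds named here, no measured pair covers this change, so any expectation for it is loose. The estimated step of an at least 2.5-fold lower number from compound 3 to compound 4 (0.39 log units; beyond the scatter) is moderate, toward stronger inhibition, and the result may again be only a limit. For compound 4 the expected value in this assay is 400000 nM, within an estimated range of 40000 nM to 1500000 nM.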

Compound 4, half-maximal inhibitory concentration: > 1000000 nM
Compound 4 gave a limit, no number (the forecaster's own chance of this, stated with the estimate: 55%); at least 2.5-fold (0.39 log units) between middle value and limit.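

Compound 3 and compound 4 each give only a limit, so the change from isobutylamino to (4-bromophenyl)amino yields no readable step. Still open, going by these compounds, is whether these two compounds differ in inhibition at all, and by how much.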